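Swapping the Aryl Group on a Sulfonamide Core

The source may report more compounds than this note shows. Statements on the series, on what has been measured and on what is new or still open speak of the compounds shown alone.

Measured compounds:
compound 1, `COc1ccc(S(=O)(=O)NC2=NCCN2C(=S)SN2CCn3c2nsc3=S)cc1OC`: >= 20000 nM
compound 2, `O=S(=O)(NC1=NCCN1C(=S)SN1CCn2c1nsc2=S)c1cccc(OC(F)(F)F)c1`: >= 20000 nM

Compound 1, with the structure `COc1ccc(S(=O)(=O)NC2=NCCN2C(=S)SN2CCn3c2nsc3=S)cc1OC`, was tested in a functional assay on KYSE-510 cells (Homo sapiens) for antiproliferative activity, read by crystal violet staining, with a stated time of 96 h; a higher number here means a weaker inhibitor of growth, a lower number a stronger inhibitor of growth. In this assay compound 1 gives >= 20000 nM, which is a limit of the assay rather than a measured number. Compound 2, `O=S(=O)(NC1=NCCN1C(=S)SN1CCn2c1nsc2=S)c1cccc(OC(F)(F)F)c1`, gives >= 20000 nM in this assay, again a limit. (the limit of >= 20000 nM in this assay, at which 2 of the 2 values shown sit). Among the compounds with values here, compound 1 thus stands at the limit, and the one further value shown sits there as well, so no measured step between compounds is available. Compound 3, `O=S(=O)(NC1=NCCN1C(=S)SN1CCn2c1nsc2=S)c1cc(Cl)cc(Cl)c1`, differs from compound 1 by 3,5-dichlorophenyl in place of 3,4-dimethoxyphenyl on a sulfonyl sulfur. With both known values at the limit, the step from compound 1 to compound 3 is expected to be a number no higher from compound 1 to compound 3 (the limit leaves the size open), meaning no shift beyond the scatter. Compound 3 is therefore estimated at 20000 nM, within a range from 8000 nM to 50000 nM.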

Compound 3, concentration for 50% growth inhibition: >= 20000 nM
Compound 3: only a limit was reported; the forecaster's own chance of this, stated with the estimate: 75%; the middle value sits exactly at the limit.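

Within the data shown here, compound 1 and compound 3 both stand at a limit in this assay, so no step between them can be read: the limit of >= 20000 nM in this assay, at which 3 of the 3 values shown sit. The compounds shown leave open how these aryl groups on the shared core would rank, and whether any of them inhibits growth measurably.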